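Aromatic substituent changes on the shared core of compound 1

A few compounds are considered here, and "the series" means these few. Any claim that something is new, unique, unknown or untested is made for them only; others in the source may bear on it.

Measured so far:
compound 1 `COc1cc(C(=O)c2sc(-c3ccc(Cl)c(Cl)c3)cc2N)cc(OC)c1OC` gives 260 nM
compound 2 `CCOc1ccc(-c2cc(N)c(C(=O)c3cc(OC)c(OC)c(OC)c3)s2)cc1` gives 590 nM
compound 3 `COc1cc(C(=O)c2sc(-c3ccsc3)cc2N)cc(OC)c1OC` gives 12 nM

The read-out throughout is a functional assay on L1210 cells (Mus musculus) for antiproliferative activity; on this read-out higher numbers stand for weaker inhibition and lower numbers for stronger inhibition. Compound 1 stands second highest of the three numbers; its nearest neighbour is compound 2, through a 2.3-fold higher number from compound 1 to compound 2 (0.36 log units; beyond the scatter), and its furthest is compound 3, through a 22-fold lower number from compound 1 to compound 3 (1.34 log units; beyond the scatter).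

Compound 4 `COc1ccc(-c2cc(N)c(C(=O)c3cc(OC)c(OC)c(OC)c3)s2)cc1OC` is not yet measured. It differs from compound 1 in one place: 3,4-dimethoxyphenyl in place of 3,4-dichlorophenyl on an aromatic carbon. The step from compound 1 to compound 2 bears on it most, as that step also swaps the 3,4-dichlorophenyl for a phenyl carrying an alkoxy group, and it was modest. Among the compounds with values here, no measured step exchanges chlorine for methoxy at both positions. A modest rise, or nothing beyond the scatter, is therefore expected in this assay, as a 1.6-fold higher number from compound 1 to compound 4 (0.21 log units; within the scatter). Compound 4 is estimated at 420 nM, within 150 nM to 1200 nM.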

Compound 4, half-maximal inhibitory concentration: 40 nM
For compound 4 the middle estimate is 11-fold (1.02 log units) above the measured one; measured number below the stated range.
By their numbers in this assay, from the lowest: compound 3; then compound 4; then compound 1; then compound 2.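

In this assay, on the carbon next to the ring sulfur, 3,4-dimethoxyphenyl gives a 6.5-fold lower number from compound 1 to compound 4 (0.81 log units; beyond the scatter) and so shows that replacing 3,4-dichlorophenyl with an alkoxy-bearing phenyl need not raise the number. These phenyls do not behave as one class, as 3,4-dimethoxyphenyl gives a 15-fold lower number from compound 2 to compound 4 (1.17 log units; beyond the scatter) while thiophen-3-yl remains lowest, with a 3.3-fold higher number from compound 3 to compound 4 (0.52 log units; beyond the scatter) for the reverse exchange. No measured evidence accounts for these differences.

Going by these compounds, whether either methoxy group alone carries the gain remains open. So does the outcome with an amine or a carboxylic acid on the phenyl ring at this position.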